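Removing the Basic Piperidine from the Potent Sulfonamide Lead

The source may report more compounds than this note shows. Statements on the series, on what has been measured and on what is new or still open speak of the compounds shown alone.

Going by the values given here, compound 1 `Cc1cc(C)c(S(=O)(=O)N2CCC(N3CCC(C(C)C)CC3)CC2)c(C)c1` is the strongest of the numbers so far: in a functional assay on DLD-1 cells (Homo sapiens) for antiproliferative activity, read by CellTiter-Glo, with a stated time of 72 h (on this read-out lower numbers stand for stronger inhibition and higher numbers for weaker inhibition), compound 1 gives 0.3 nM, the lowest of the two numerical values in the set. Compound 2 `Cc1cc(C)c(S(=O)(=O)N2CCC(N3CCC(c4ccccc4)CC3)CC2)c(C)c1` gives 865 nM, and compound 3 `Cc1cc(C)c(S(=O)(=O)N2CCC(N3CCC(CCC#N)CC3)CC2)c(C)c1` returns only a limit of the assay, > 5000 nM (the limit of > 5000 nM in this assay, at which 1 of the 3 values shown sits).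

The step to compound 4 `CCCC(=O)NC1CCN(S(=O)(=O)c2c(C)cc(C)cc2C)CC1` changes a different part of the molecule from the steps already measured: (propylcarbonyl)amino in place of 4-isopropylpiperidin-1-yl on a saturated ring carbon. Among the compounds with values here, no measured step removes the whole saturated ring; the nearest evidence is that even a change confined to its substituent costs a great deal, a 2900-fold higher number from compound 1 to compound 2 (3.46 log units; beyond the scatter) and an at least 16000-fold higher number from compound 1 to compound 3 (4.22 log units; beyond the scatter), with an at least 5.7-fold higher number from compound 2 to compound 3 (0.76 log units; beyond the scatter) between them. Since the entering (propylcarbonyl)amino group has no ring and brings a hydrogen-bond donor, a still larger loss in this assay is expected, in the direction of a higher number, a 17000-fold higher number from compound 1 to compound 4 (4.22 log units; beyond the scatter). Compound 4 is therefore estimated at 5000 nM, within 500 nM to 50000 nM, with a fair chance of only a limit.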

Compound 4, half-maximal inhibitory concentration: > 5000 nM
Compound 4: no number, only a limit; the forecaster's own chance of this, stated with the estimate: 55%; the middle value lies on the limit itself.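

Compound 4 gives no number in this assay, only a limit, the second such result in the set: the limit of > 5000 nM in this assay, at which 2 of the 4 values shown sit. The earlier steps shown here changed only the substituent on the saturated ring, whereas this one replaces the entire 4-isopropylpiperidin-1-yl group with (propylcarbonyl)amino, giving an at least 16000-fold higher number from compound 1 to compound 4 (4.22 log units; beyond the scatter). The activity of compound 1 is therefore not retained with this open-chain amide at the position, although the full size of the loss cannot be read past the limit.

The compounds shown do not separate the contribution of the ring nitrogen from that of the ring carbons; a 4-isopropylcyclohexyl group or an open-chain amine such as diisopropylamino in the same place would address this. Also open, from the compounds shown here alone, is whether an ethyl or tert-butyl group on the piperidine would keep the activity seen with isopropyl.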